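Replacing the Amide Aryl Group by a Furan Ring

The source may hold more compounds than are shown below. What is called first, only, known or untested is meant among the compounds shown, and "the series" means these compounds.

Measured compounds:
compound 1 `CC(=O)Nc1c(C(O)(C(F)(F)F)C(F)(F)F)ccc2ccccc12` — 87%
compound 2 `O=C(Nc1c(C(O)(C(F)(F)F)C(F)(F)F)ccc2ccccc12)c1cccc(Cl)c1` — 84%

Both compounds share one core and differ only in the group carried on the carbonyl carbon of the amide. In a functional assay (Sus scrofa) with sulfonylurea receptors; K-ATP channels (Homo sapiens) as the target (on this read-out lower numbers stand for smaller maximal responses and higher numbers for larger maximal responses), compound 1 gives 87%, and compound 2 gives 84%. Going by the values given here, the one step between them, a number 3 percentage points lower from compound 1 to compound 2 (within the scatter), shows that exchanging methyl for 3-chlorophenyl left the maximal response essentially unchanged; compound 2 and compound 1 therefore lie within the usual scatter of each other.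

Compound 3 `O=C(Nc1c(C(O)(C(F)(F)F)C(F)(F)F)ccc2ccccc12)c1ccco1` differs from compound 2 in one place: furan-2-yl in place of 3-chlorophenyl on a carbonyl carbon. Among the compounds with values here, no measured pair shows an aromatic ring exchanged for a five-membered heteroaromatic ring at this position, so the only guidance is the earlier step on the same carbonyl carbon, which stayed within the scatter. The step of no change at the digits printed from compound 2 to compound 3 (within the scatter) is therefore expected to be small, with no clear direction. Compound 3 is estimated at 84%, with a range from 70% to 96%.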

Compound 3, largest response reached (reported as efficacy), in percent of the reference or control that the assay uses: 96%
Compound 3: the middle estimate sits 12 percentage points below what was measured; the measured number falls inside the stated range.
By their numbers in this assay, from the lowest: compounds 2, 1 and 3 (each within the scatter of the next, the first and the last beyond it).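

In this assay, the carbonyl carbon of the amide now shows that an exchange here can move the maximal response: furan-2-yl in place of 3-chlorophenyl gives a number 12 percentage points higher from compound 2 to compound 3 (beyond the scatter), a step beyond the scatter, unlike the earlier step at this position. Set against methyl, the same ring gives a number 9 percentage points higher from compound 1 to compound 3 (within the scatter), so furan-2-yl stands apart from 3-chlorophenyl but not from methyl. Nothing available here bears on what lies behind this difference.

The compounds shown leave open whether the higher number belongs to furan-2-yl alone or would also appear with thiophen-2-yl, which has a sulfur atom in place of the ring oxygen. They also leave open whether plain phenyl, without the chlorine, would fall with compound 2 or with compound 3.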